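The source may report more compounds than this note shows. Statements on the series, on what has been measured and on what is new or still open speak of the compounds shown alone.

Four close relatives built on one core are compared for how well a human monocyte cell line tolerates them, in an ADME assay on THP-1 cells (Homo sapiens) for cytotoxicity, read by MTT assay, with a stated time of 72 h; a lower number here means that less compound is tolerated, a higher number that more compound is tolerated. Compound 1, `O[C@@H]1Cc2cc(Cl)ccc2N[C@H](c2ccccc2)C1`, gives 188000 nM. Compound 2, `O[C@@H]1Cc2cc(F)ccc2N[C@H](c2ccccc2)C1`, differs from it by fluoro in place of chloro on an aromatic carbon. For compound 2 this assay reports only a limit, > 300000 nM. That change makes an at least 1.5-fold higher number from compound 1 to compound 2 (0.20 log units; that floor lies within the scatter).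

Compound 3, `O[C@@H]1Cc2ccccc2N[C@H](c2ccccc2Cl)C1`, carries its chloro on the other aromatic ring, and the difference between its core and that of compound 1 is not broken down here. For compound 3 this assay again reports only a limit, > 300000 nM.

Compound 4, `O[C@@H]1Cc2ccccc2N[C@H](c2ccccc2F)C1`, is not yet measured and differs from compound 3 by fluoro in place of chloro on an aromatic carbon. Among the compounds with values here, this is the same kind of change as the one from compound 1 to compound 2, but not the same: there the swap sat on a ring that is part of a fused or bridged system of two rings, meta to a fused ring and para to a fused ring, whereas here it sits on a six-membered aromatic ring of carbon only, ortho to a large group.

The step expected from this change is a step that the limit leaves unreadable from compound 3 to compound 4, which rests on compound 3 because the limit of > 300000 nM in this assay, at which 2 of the 3 values shown sit, already lies where compound 3 is read. Compound 4 is therefore estimated to give 350000 nM, within the range 200000 nM to 800000 nM, and most likely this assay will again report only a limit.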

Compound 4, half-maximal cytotoxic concentration: > 300000 nM
Compound 4: only a limit was reported; the forecaster's own chance of this, stated with the estimate: 80%; the middle value lies beyond the limit too.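

Compound 3 and compound 4 are both reported only as limits in this assay, so no step between them can be read, and the evidence for this is: the limit of > 300000 nM in this assay, at which 3 of the 4 values shown sit.

The compounds shown leave open how much of compound 2, compound 3 or compound 4 the cells tolerate past that limit, and so how large the effect of fluoro in place of chloro is on the ring of compound 3.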